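A few compounds are considered here, and "the series" means these few. Any claim that something is new, unique, unknown or untested is made for them only; others in the source may bear on it.

Compound 1 `C#CCN(CCCCOc1ccc2ccc(=O)oc2c1)Cc1ccc(C(C)C)cc1`: 3500 nM
Compound 2 `C#CCN(CCCOc1ccc2ccc(=O)oc2c1)Cc1ccccc1`: 3740 nM

In an assay on isolated protein for inhibition of Amine oxidase [flavin-containing] B (Homo sapiens), read by fluorescence and Amplex Red, with stated times of 15 min and 20 min (on this read-out lower numbers stand for stronger inhibition and higher numbers for weaker inhibition), compound 1 gives the lowest of the two numbers, yet compound 2 lies within the scatter of it, so the two are not distinguished. Compound 3 `C#CCN(C)CCCCOc1ccc2ccc(=O)oc2c1` is not yet measured. It differs from compound 1 by hydrogen in place of 4-isopropylphenyl on a saturated chain carbon bound to an amine nitrogen. Going by the values given here, no measured pair differs in one place, so no step of this kind is known from the series. Removing the 4-isopropylbenzyl group is expected to weaken inhibition in this assay by a moderate amount, beyond the scatter. The expected step is a 2.6-fold higher number from compound 1 to compound 3 (0.41 log units; beyond the scatter). Compound 3 is estimated at 9000 nM, with a range of 2500 nM to 30000 nM.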

Compound 3, half-maximal inhibitory concentration: 27 nM
Compound 3: the middle estimate sits 330-fold (2.52 log units) above what was measured, outside the stated range (below it).
By their numbers in this assay, from the lowest: compound 3; then compounds 1 and 2 (each within the scatter of the next).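

The change from 4-isopropylbenzyl to methyl gives a 130-fold lower number from compound 1 to compound 3 (2.11 log units; beyond the scatter) in this assay. This position on the amine nitrogen is therefore highly sensitive, and the 4-isopropylphenyl group is not required for strong inhibition in this assay. Nothing available accounts for the size of this step.

Open, from the compounds shown here alone, is how inhibition changes between these two extremes, for example with ethyl or cyclopropylmethyl on the amine nitrogen. Also open, going by these compounds, is whether a longer chain to the core keeps the inhibition seen with compound 3.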